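Swapping Chloro for Fluoro on a Thienopyridine Carboxamide Series

The source may hold more compounds than are shown below. What is called first, only, known or untested is meant among the compounds shown, and "the series" means these compounds.

Measured so far:
Compound 1, `NC(=O)c1c(NC(=O)c2ccccc2Cl)sc2c1CCN(Cc1ccccc1Cl)C2`: 4430 nM
Compound 2, `NC(=O)c1c(NC(=O)c2ccccc2Cl)sc2c1CCN(Cc1ccccc1F)C2`: 12900 nM
Compound 3, `NC(=O)c1c(NC(=O)c2ccccc2Cl)sc2c1CCN(C(=S)Nc1cc(C(F)(F)F)cc(C(F)(F)F)c1)C2`: 15000 nM

All three compounds share one core and were tested in a functional assay on MKN-74 cells (Homo sapiens) for antiproliferative activity, with a stated time of 24 h; a higher number here means a weaker inhibitor, a lower number a stronger inhibitor. Compound 1 gives 4430 nM. Compound 2 differs from compound 1 by fluoro in place of chloro on an aromatic carbon, and this brought a 2.9-fold higher number from compound 1 to compound 2 (0.46 log units; beyond the scatter). Compound 3 carries a different group on the ring nitrogen of the core; how its core differs from that of compound 1 is not broken down here. In this assay compound 3 gives 15000 nM, which stands within the usual scatter of the value of compound 2 and beyond it from compound 1.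

Compound 4, `NC(=O)c1c(NC(=O)c2ccccc2F)sc2c1CCN(C(=S)Nc1cc(C(F)(F)F)cc(C(F)(F)F)c1)C2`, has not yet been measured. It differs from compound 3 by fluoro in place of chloro on an aromatic carbon. The place is described in the same words as the change from compound 1 to compound 2, so this is the same change, made on a second pair. Because of the step of a 2.9-fold higher number from compound 1 to compound 2 (0.46 log units; beyond the scatter), a weaker inhibitor than compound 3 is expected, with an estimated step of a 2.3-fold higher number from compound 3 to compound 4 (0.37 log units; beyond the scatter). The expectation rests on a single earlier pair, so the range is kept wide. Compound 4 is estimated at 35000 nM, between 12000 nM and 100000 nM.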

Compound 4, half-maximal inhibitory concentration: 13300 nM
The estimate for compound 4 lay 2.6-fold (0.42 log units) above the measured number; low and high end bracket the measured number.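

In this assay, fluoro in place of chloro brought a 1.1-fold lower number from compound 3 to compound 4 (0.05 log units; within the scatter), so the loss seen on the first pair did not carry over to this second pair: the same change on two cores in this assay, a 2.9-fold higher number (0.46 log units; beyond the scatter) from compound 1 to compound 2 and a 1.1-fold lower number (0.05 log units; within the scatter) from compound 3 to compound 4, 3.3-fold (0.52 log units) apart, beyond the scatter of two such steps

This shows that the effect of this swap cannot simply be transferred from one compound pair to another in this series, even though the change is described in the same words. It does not show why, since the two pairs differ in two ways at once: the swap falls on the group on the ring nitrogen in the first pair and on the (2-chlorophenyl)carbonyl group in the second, and the group on the ring nitrogen is also different. A step within the scatter also shows only that any effect of the swap from compound 3 to compound 4 is too small to be told from repeat variation here, not that the swap can never matter on this core.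

The compounds shown leave open what a compound would give if it joined the ring-nitrogen group of compound 1 to the (2-fluorophenyl)carbonyl group, which would help separate those two differences. They also leave open how hydrogen, bromo, methyl or a nitrile would behave in place of the halogen at either site.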